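Heptyl for methoxy on the aryl ring of compound 3

The compounds below may be only part of what the source reports. "The series", "measured", "known", "first", "only" and "open" are said of these compounds alone.

Three members of the series have numbers in a functional assay on brain (Rattus norvegicus, strain Wistar) for inhibition; on this read-out lower numbers stand for stronger inhibition and higher numbers for weaker inhibition. Compound 1 `CCCCc1ccc(-c2c(C)[nH]c(=O)n2C)cc1` gives 10700 nM. Compound 2 `COc1ccc(-c2c(C)[nH]c(=O)n2C)cc1` gives 147000 nM, and the step of a 14-fold higher number from compound 1 to compound 2 (1.14 log units; beyond the scatter) covers the exchange of the butyl for a methoxy on the aromatic carbon. Compound 3 `COc1ccc(-c2c(C)[nH]c(=O)n2C2CCCCC2)cc1` gives 20400 nM, and the step of a 7.2-fold lower number from compound 2 to compound 3 (0.86 log units; beyond the scatter) covers the cyclohexyl in place of the methyl on the aromatic nitrogen. On these numbers compound 3 sits within the scatter of compound 1 and clearly lower than compound 2; compound 3 and compound 1 are not separated by this assay.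

Compound 4 `CCCCCCCc1ccc(-c2c(C)[nH]c(=O)n2C2CCCCC2)cc1` differs from compound 3 in one respect: heptyl in place of methoxy on an aromatic carbon. Within the data shown here, the only measured step at the same position is a 14-fold higher number from compound 1 to compound 2 (1.14 log units; beyond the scatter), and the present change runs in the opposite sense, a chain in place of the methoxy, on a core that already carries the cyclohexyl. Whether a heptyl behaves as the butyl did is shown by no pair here; no measured compound carries a chain of that length. The expectation for compound 4 is therefore a lower number than compound 3, of a size near the reverse of that step, giving a 10-fold lower number from compound 3 to compound 4 (1.01 log units; beyond the scatter). Compound 4 is estimated at 2000 nM in this assay, with a range from 500 nM to 10000 nM.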

Compound 4, half-maximal inhibitory concentration: 8700 nM
For compound 4 the middle estimate is 4.4-fold (0.64 log units) below the measured one; the range from low to high includes it.
By their numbers in this assay, from the lowest: compounds 4, 1 and 3 (each within the scatter of the next, the first and the last beyond it); then compound 2.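

In this assay the position on the aromatic carbon still responds once the cyclohexyl is in place: heptyl in place of methoxy gives a 2.3-fold lower number from compound 3 to compound 4 (0.37 log units; beyond the scatter), so on both nitrogen substituents the alkyl chain carries the lower number, read against a 14-fold higher number from compound 1 to compound 2 (1.14 log units; beyond the scatter), which runs from chain to methoxy on the methyl core. The step on the cyclohexyl core is the smaller of the two, modest against large, but the two pairs differ in both the chain and the nitrogen substituent, so the difference in size cannot be assigned to either one. Nothing at hand gives a reason for the direction or the size of this step.

Butyl and heptyl do not stand on the same core here, so how the number follows chain length remains open, and a butyl on the cyclohexyl core or a heptyl on the methyl core would separate the two influences. Also open, as far as these compounds go, is whether a still longer chain such as decyl, or a heptyl ending in an amine or a carboxylic acid, would keep the lower number.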